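Fluoro for Methoxy: An Expected Assay Limit

The source may hold more compounds than are shown below. What is called first, only, known or untested is meant among the compounds shown, and "the series" means these compounds.

Compound 2 `COc1cc(O[C@H]2C[C@H](OC)C2)cc(-c2ccc3c(c2)CC[C@H](CCc2nnn[nH]2)O3)c1F` carries a (3-methoxycyclobutyl)oxy group on an aromatic ring. In a functional assay on HEK293 cells for agonist activity at Free fatty acid receptor 1 (Homo sapiens), read by HTRF and inositol phosphate accumulation, with a stated time of 60 min (a higher number here means that more compound is needed for the effect, a lower number that less compound is needed), compound 2 gives only a limit, > 10000 nM. Its nearest measured relative is compound 1 `COc1cc(OC(F)(F)F)cc(-c2ccc3c(c2)CC[C@H](CCc2nnn[nH]2)O3)c1F`, which bears trifluoromethyl on the same oxygen. In this assay compound 1 likewise returns a limit, > 10000 nM. The change of 3-methoxycyclobutyl in place of trifluoromethyl on an oxygen on an aromatic ring is a step that the two limits leave unreadable from compound 1 to compound 2. Both measured values sit at the limit of > 10000 nM in this assay, at which 2 of the 2 values shown sit.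

Compound 3 `CO[C@H]1C[C@H](Oc2cc(F)c(F)c(-c3ccc4c(c3)CC[C@H](CCc3nnn[nH]3)O4)c2)C1` differs from compound 2 by fluoro in place of methoxy on an aromatic carbon. Among the compounds with values here, no measured step bears directly on this exchange, and the one step available is unreadable; no size or direction of step in this assay can be read from the data. Compound 3 is expected to remain at the limit. The step for compound 3 is estimated as a step that the limit leaves unreadable from compound 2 to compound 3. The estimate for compound 3 is 15000 nM, with a range from 3000 nM to 60000 nM.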

Compound 3, half-maximal effective concentration: > 10000 nM
Compound 3: no number, only a limit; the forecaster's own chance of this, stated with the estimate: 80%; the middle value lies beyond the limit too.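

Compound 2 and compound 3 both give only a limit in this assay, so no step between them can be read: the limit of > 10000 nM in this assay, at which 3 of the 3 values shown sit.

The compounds shown leave open whether fluoro in place of methoxy, or 3-methoxycyclobutyl in place of trifluoromethyl, changes the concentration needed for the effect.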